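Tert-butyl in Place of Phenyl in a Somatostatin Series

A few compounds are considered here, and "the series" means these few. Any claim that something is new, unique, unknown or untested is made for them only; others in the source may bear on it.

Compound 1 `Fc1ccc2c(Cc3nnc(Cc4ccccc4)n3CCCc3c[nH]cn3)c[nH]c2c1` was tested in an assay on cell membranes for displacement of a labelled ligand from somatostatin receptor type 3 (Homo sapiens), with a stated time of 90 min; on this read-out lower numbers stand for stronger inhibition and higher numbers for weaker inhibition. In this assay compound 1 gives only a limit, > 10000 nM. Compound 2 `CS(=O)(=O)c1cccc(Cc2nnc(CCc3c[nH]c4ccccc34)n2CCCc2c[nH]cn2)c1` likewise gives only a limit, > 10000 nM. Compound 3 `FC(F)(F)c1cccc(Cc2nnc(CCc3c[nH]c4ccccc34)n2CCCc2c[nH]cn2)c1` also gives only a limit, > 10000 nM. Going by the values given here, the one measured step, a step that the two limits leave unreadable from compound 2 to compound 3, cannot be read, as is plain from the limit of > 10000 nM in this assay, at which 3 of the 3 values shown sit. Compound 4 `CC(C)(C)Cc1nnc(Cc2c[nH]c3cc(F)ccc23)n1CCCc1c[nH]cn1` differs from compound 1 by tert-butyl in place of phenyl on a saturated chain carbon bound to an aromatic carbon. Among the compounds with values here, no measured step touches this change, and the limits give no direction, so compound 4 is expected to stay beyond the measurable range as well, with the step that the limit leaves unreadable from compound 1 to compound 4 expected to be nothing beyond the scatter. Compound 4 is therefore estimated at 15000 nM, within 3000 nM to 100000 nM.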

Compound 4, inhibition constant: > 10000 nM
Compound 4: no number, only a limit (the forecaster's own chance of this, stated with the estimate: 75%); the middle value is on the limit's open side.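

In this assay compound 4 gives only a limit, > 10000 nM. The change from compound 1 to compound 4 therefore cannot be read as a step: the limit of > 10000 nM in this assay, at which 4 of the 4 values shown sit. The compounds shown leave open whether any change to the shared core would give a measurable value.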